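Acetyl for Fluoro: Expecting Another Limit in Cytotoxicity

The compounds below may be only part of what the source reports. "The series", "measured", "known", "first", "only" and "open" are said of these compounds alone.

Three ureas sharing one core have been examined in an ADME assay on BJ cells (Homo sapiens) for cytotoxicity, with a stated time of 72 h; on this read-out lower numbers stand for an effect already at smaller amounts and higher numbers for an effect only at larger amounts of compound. Compound 1 `Cc1cc(NC(=O)Nc2ccc(C(=O)O)cc2)c2ccccc2n1` gives only a limit there, > 25000 nM. Compound 2 `Cc1cc(NC(=O)Nc2ccc(N)cc2)c2ccccc2n1` likewise gives a limit, > 25000 nM. Compound 3 `Cc1cc(NC(=O)Nc2ccc(F)cc2)c2ccccc2n1` also reaches no more than a limit, > 25000 nM. Hence the steps a step that the two limits leave unreadable from compound 1 to compound 2, a step that the two limits leave unreadable from compound 1 to compound 3 and a step that the two limits leave unreadable from compound 2 to compound 3 cannot be sized, and compound 3 stands with the other two at the limit of > 25000 nM in this assay, at which 3 of the 3 values shown sit. Compound 4 `CC(=O)c1ccc(NC(=O)Nc2cc(C)nc3ccccc23)cc1` differs from compound 3 as follows: acetyl in place of fluoro on an aromatic carbon. No measured step can be read, so no shift beyond the scatter in either direction is expected in this assay. The estimated step that the limit leaves unreadable from compound 3 to compound 4 therefore expresses no expected change. Compound 4 is expected to give about 40000 nM in this assay, within 15000 nM to 120000 nM, most probably again as a limit.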

Compound 4, half-maximal effective concentration: 22000 nM
The estimate for compound 4 lay 1.8-fold (0.26 log units) above the measured number; the measured number falls inside the stated range.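

In this assay, among these compounds, acetyl at this place, on an aromatic carbon para to a large group, gives the only number of the four rather than a limit: the limit of > 25000 nM in this assay, at which 3 of the 4 values shown sit. The new steps read as an at least 1.1-fold lower number from compound 3 to compound 4 (0.05 log units; that floor lies within the scatter) and an at least 1.1-fold lower number from compound 2 to compound 4 (0.05 log units; that floor lies within the scatter) and an at least 1.1-fold lower number from compound 1 to compound 4 (0.05 log units; that floor lies within the scatter) and so all three floors lie within the scatter. This change is therefore not shown to move the read-out beyond the scatter.

The steps among compound 1, compound 2 and compound 3 still cannot be read. As far as these compounds go, whether a nitrile or a longer acyl chain at this place would also give a number stays open.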